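Swapping a methoxy for a chloro on a thiazolidinedione agonist

The source may hold more compounds than are shown below. What is called first, only, known or untested is meant among the compounds shown, and "the series" means these compounds.

Three compounds have been measured:

Compound 1, `O=C1NC(=O)C(Cc2ccc(Cc3ccccc3)cc2)S1`: 9280 nM
Compound 2, `COc1cc(Oc2ncc(C(F)(F)F)cc2Cl)ccc1CC1SC(=O)NC1=O`: 13900 nM
Compound 3, `Cc1cc(Oc2ccc(C(F)(F)F)cc2Cl)ccc1CC1SC(=O)NC1=O`: 18 nM

The read-out throughout is a functional assay for agonist activity at Free fatty acid receptor 1 (Homo sapiens), read by FLIPR, in the presence of a further agent that is not named here (a lower number here means that less compound is needed, a higher number that more compound is needed for the effect), and the three compounds share the same core. Compound 2 has the highest of the three numbers. Compound 1 sits close to it, with the gap between compound 1 and compound 2 within the scatter, so nothing can be said about which of the two is the more active. Compound 3 stands far away: the gap from compound 3 to compound 2 is beyond the scatter, and it differs from compound 2 in more than one place, so no single change can be credited for that gap.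

Compound 4, `O=C1NC(=O)C(Cc2ccc(Oc3ncc(C(F)(F)F)cc3Cl)cc2Cl)S1`, has not yet been measured. Relative to compound 2 the change is chloro in place of methoxy on an aromatic carbon.

Among the compounds with values here, no single-point step between measured compounds exists to lean on here. Given that compound 3 shows 18 nM on the same core, while compound 2 with its methoxy shows 13900 nM, a move to a lower number is expected, of moderate size rather than closing the whole distance. The estimated step of a 14-fold lower number from compound 2 to compound 4 (1.14 log units; beyond the scatter) is expected to lie beyond the scatter. For compound 4 the expected value is 1000 nM, with a likely range from 150 nM to 7000 nM.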

Compound 4, half-maximal effective concentration: 26 nM
The estimate for compound 4 lay 38-fold (1.59 log units) above the measured number; the measured number lies below the stated range.
By their numbers in this assay, from the lowest: compounds 3 and 4 (each within the scatter of the next); then compounds 1 and 2 (each within the scatter of the next).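

In this assay, putting chloro in place of methoxy on the aromatic carbon ortho to a (2,4-dioxo-1,3-thiazolidin-5-yl)methyl group gives a 530-fold lower number from compound 2 to compound 4 (2.73 log units; beyond the scatter), and nothing else in the molecule changes. Within the data shown here, this is the first step here that ties a large shift to one place, since the gaps among the earlier compounds could not be credited to any single change. It shows that this aromatic carbon is highly sensitive to what it carries, and that compound 2 owes its high number to the methoxy and not to the rest of its structure; the compounds shown carry no measurement that would explain why the exchange matters so much.

On these data alone, whether chloro is special remains open: a fluoro, a bromo, an ethyl or a nitrile on this same carbon would show if other groups also keep the number low. Compound 3 carries a methyl on the corresponding carbon but also differs from compound 4 elsewhere, so the effect of methyl alone, and of a bare hydrogen at this place, cannot be separated from the other differences.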